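This account rests on a few compounds, and the source may have more. Where it says the series, first, only, none or still open, it means among the compounds named here.

Notes on the series. Compound 1 `Cc1ccc(/C=C2\S/C(=N\c3csc(-c4ccc(Cl)cc4)c3)NC2=O)cc1` gives 1500 nM in a functional assay on SW-620 cells (Homo sapiens) for cytotoxicity, read by MTT assay, with a stated time of 72 h; a higher number here means a weaker inhibitor, a lower number a stronger inhibitor. Compound 2 `CN(C)c1ccc(/C=C2\S/C(=N\c3csc(-c4ccc(Cl)cc4)c3)NC2=O)cc1` gives 800 nM in this assay. Among the measured compounds shown here, compound 3 `CN(C)c1ccc(/C=C2\S/C(=N\c3nc(-c4ccc(Cl)cc4)cs3)NC2=O)cc1` gives 200 nM in this assay, the lowest of the three numbers measured so far, and its steps to compound 2 and to compound 1 are both beyond the scatter. The difference between the core of compound 3 and the core of compound 2 is not broken down here.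

Compound 2 and compound 1 differ in one place, by methyl in place of dimethylamino on an aromatic carbon. This change gave a 1.9-fold higher number from compound 2 to compound 1 (0.27 log units; within the scatter).

Compound 4 `Cc1ccc(/C=C2\S/C(=N\c3nc(-c4ccc(Cl)cc4)cs3)NC2=O)cc1` is not yet measured. It differs from compound 3 by methyl in place of dimethylamino on an aromatic carbon. The place is the same word for word as in the change from compound 2 to compound 1, so this is the same change, now made on the core of compound 3. For the measured compounds named here, only one earlier instance exists and it lies within the scatter, so the direction of the step is uncertain. Compound 4 is expected to give 400 nM in this assay, between 200 nM and 800 nM. This expectation rests on compound 3 at 200 nM and on the earlier step of a 1.9-fold higher number from compound 2 to compound 1 (0.27 log units; within the scatter). The expected step is a 2.0-fold higher number from compound 3 to compound 4 (0.30 log units; within the scatter).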

Compound 4, half-maximal inhibitory concentration: 890 nM
Compound 4: the middle estimate sits 2.2-fold (0.35 log units) below what was measured; measured number outside the range, above it.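

In this assay, methyl in place of dimethylamino gave a 4.5-fold higher number from compound 3 to compound 4 (0.65 log units; beyond the scatter), a step that can be read on its own on this core. The two instances of the change do not differ beyond what repeated measurement allows: the same change on two cores in this assay, a 1.9-fold higher number (0.27 log units; within the scatter) from compound 2 to compound 1 and a 4.5-fold higher number (0.65 log units; beyond the scatter) from compound 3 to compound 4, 2.4-fold (0.38 log units) apart, within the scatter of two such steps. This is compatible with the change carrying from one core to the other, but it rests on only two instances, one of which lies within the scatter, so it neither establishes a shared direction nor shows that the step is larger on the core of compound 3 than on the core of compound 2.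

Only dimethylamino and methyl appear at this place, so the compounds shown leave open whether a primary amine, a methoxy group or a halogen there would follow the step seen with methyl. Going by these compounds, it also remains open whether the step would recur on a third core, or with the chlorine on the other aromatic ring replaced by a different group.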